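Swapping the aryl amine substituent on compound 3

A few compounds are considered here, and "the series" means these few. Any claim that something is new, unique, unknown or untested is made for them only; others in the source may bear on it.

Going by the values given here, compound 3 (`Cc1cc(Br)ccc1Nc1c(-c2ccc3[nH]nc(C)c3c2)nc2cnc(N3CCN(C)CC3)cn12`) sits second among the three measured members in a functional assay on MV4-11 cells (Homo sapiens) for inhibition, with a stated time of 120 h, tested at 10 uM (on this read-out higher numbers stand for more inhibition at the one concentration tested (going by the name of the read-out) and lower numbers for less inhibition), where compound 3 gives 59.4%; compound 2 (`Cc1n[nH]c2ccc(-c3nc4cnc(N5CCN(C)CC5)cn4c3Nc3ccc(Br)cc3)cc12`) gives 83% and compound 1 (`Cc1n[nH]c2ccc(-c3nc4cnc(N5CCN(C)CC5)cn4c3Nc3cccc(F)c3)cc12`) gives 18.5%. The difference a number 23.6 percentage points lower from compound 2 to compound 3 (beyond the scatter) shows that the methyl costs some inhibition, while a number 64.5 percentage points higher from compound 1 to compound 2 (beyond the scatter) and a number 40.9 percentage points higher from compound 1 to compound 3 (beyond the scatter) show that the number is far higher with a 4-bromophenyl or 4-bromo-2-methylphenyl group than with a 3-fluorophenyl group. Compound 4 (`Cc1n[nH]c2ccc(-c3nc4cnc(N5CCN(C)CC5)cn4c3Nc3ccc(Cl)cc3Cl)cc12`) arises from compound 3 by the change (2,4-dichlorophenyl in place of 4-bromo-2-methylphenyl on a nitrogen on an aromatic ring). Among the compounds with values here, no measured step matches a halogen-for-halogen or chlorine-for-methyl exchange at this position, so the estimate leans on the fact that compound 4 keeps a substituent at the 4-position and a substituent at the 2-position, as in compound 3. Compound 4 is therefore expected to show a step of a number 4.4 percentage points lower from compound 3 to compound 4 (within the scatter). Compound 4 is estimated at 55%, in the range 30% to 80%.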

Compound 4, a percentage reported as inhibition, at one concentration (the size of the read-out at that concentration, not a potency): 78.8%
Beside the measured number, compound 4's estimate is 23.8 percentage points below it; low and high end bracket the measured number.
By their numbers in this assay, from the lowest: compound 1; then compound 3; then compounds 4 and 2 (each within the scatter of the next).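

In this assay, a number 19.4 percentage points higher from compound 3 to compound 4 (beyond the scatter) shows that 2,4-dichlorophenyl and 4-bromo-2-methylphenyl are not interchangeable on this nitrogen, although both groups have the same heavy-atom count. a number 4.2 percentage points lower from compound 2 to compound 4 (within the scatter) then puts the 2,4-dichlorophenyl group level with 4-bromophenyl, so a second substituent on this ring does not always lower the number as the methyl of compound 3 did, and a number 60.3 percentage points higher from compound 1 to compound 4 (beyond the scatter) adds a third aryl group that stands well clear of 3-fluorophenyl. Nothing at hand explains why the dichloro and methyl-bearing groups differ.

The compounds shown leave open how a 4-chlorophenyl or a 2-chlorophenyl group would read here, and so what each chlorine contributes. Also open, on these data alone, is whether a methoxy group or an amine on this phenyl ring would keep the number as high.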